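A Second Methylphenyl Variant of a Hydroxamic Acid Chain

A few compounds are considered here, and "the series" means these few. Any claim that something is new, unique, unknown or untested is made for them only; others in the source may bear on it.

Measured so far:
compound 1 `CCOc1ccc(CCCN2CC=C(CCC(=O)NO)C2=O)cc1`: 2200 nM
compound 2 `Cc1ccccc1CCCN1CC=C(CCC(=O)NO)C1=O`: 2200 nM

Two hydroxamic acids with a shared core have been tested in a functional assay on NUGC-3 cells (Homo sapiens) for inhibition, read by sulforhodamine B assay; a higher number here means a weaker inhibitor of growth, a lower number a stronger inhibitor of growth. Compound 1 `CCOc1ccc(CCCN2CC=C(CCC(=O)NO)C2=O)cc1` gives 2200 nM there, and compound 2 `Cc1ccccc1CCCN1CC=C(CCC(=O)NO)C1=O` gives 2200 nM. Compound 2 thus stands level with compound 1: the two values lie within the usual scatter, so no order between them can be read. Going by the values given here, no step between compounds differing in a single place is available from these two.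

Compound 3 `Cc1ccc(CCCN2CC=C(CCC(=O)NO)C2=O)cc1` differs from compound 2 in one way: 4-methylphenyl in place of 2-methylphenyl on a saturated chain carbon, three bonds along the chain from an amide-type nitrogen in a ring. Compound 1 at 2200 nM and compound 2 at 2200 nM carry different aryl groups on the same chain yet fall within the scatter of each other. On that basis the change to compound 3 is expected to bring no step beyond the scatter, with no change at the digits printed from compound 2 to compound 3 (within the scatter). Compound 3 is estimated at 2200 nM, within a range from 1100 nM to 4400 nM.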

Compound 3, concentration for 50% growth inhibition: 2200 nM
Compound 3: the middle estimate sits on the measured number at the digits printed; low and high end bracket the measured number.
By their numbers in this assay, from the lowest: compounds 1, 2 and 3 (each within the scatter of the next).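

In this assay, the place of the methyl group on the aryl ring is now tested on its own, and 4-methylphenyl in place of 2-methylphenyl on a saturated chain carbon gives no change at the digits printed from compound 2 to compound 3 (within the scatter) in this series. The group itself is also tested on its own, since methyl in place of ethoxy on an aromatic carbon gives no change at the digits printed from compound 1 to compound 3 (within the scatter), whereas compounds 1 and 2 differed in both group and place and could not separate the two. No measurement shown here offers any account of this flat result.

The compounds shown leave open whether a group of another kind on the aryl ring, such as an amine or a carboxylic acid, would also leave the growth inhibition unmoved. They also leave open whether a longer chain carrying the aryl group would do so.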